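The compounds below may be only part of what the source reports. "The series", "measured", "known", "first", "only" and "open" are said of these compounds alone.

Measured in a toxicity assay on MT4 cells (Homo sapiens) for cytotoxicity, read by MTT assay, with a stated time of 5 days; a higher number here means that more compound is tolerated, a lower number that less compound is tolerated:
- compound 1 `Cc1cc(-c2cccc3cc[nH]c23)cc(C)c1Nc1ccnc(Nc2ccc(C#N)cc2)n1`: 1000 nM
- compound 2 `Cc1ccc(-c2cc(C)c(Nc3ccnc(Nc4ccc(C#N)cc4)n3)c(C)c2)s1`: 28000 nM

Compound 2 holds the higher of the two numbers. Next is compound 3 `Cc1cc(-c2cc(C)c(Nc3ccnc(Nc4ccc(C#N)cc4)n3)c(C)c2)cc(C)n1`, with 2,6-dimethylpyridin-4-yl in place of 5-methylthiophen-2-yl on an aromatic carbon. For the measured compounds named here, the one measured step bearing on this is a 28-fold higher number from compound 1 to compound 2 (1.45 log units; beyond the scatter), a large change beyond the scatter at the same place. It shows that this assay can respond to this group, but gives no direction for the new one. A modest fall is expected, with an estimated 2.3-fold lower number from compound 2 to compound 3 (0.37 log units; beyond the scatter). The estimate for compound 3 is 12000 nM, with an expected range of 3000 nM to 40000 nM.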

Compound 3, half-maximal cytotoxic concentration: 2300 nM
Estimate against measurement, compound 3: 5.2-fold (0.72 log units) above; the whole stated range lies above it.
By their numbers in this assay, from the lowest: compound 1; then compound 3; then compound 2.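

In this assay, a change at this position is large for a second time: a 12-fold lower number from compound 2 to compound 3 (1.09 log units; beyond the scatter), so a high number does not follow from any aromatic group placed here. Against the 1H-indol-7-yl group, the change is smaller, a 2.3-fold higher number from compound 1 to compound 3 (0.36 log units; beyond the scatter), leaving 5-methylthiophen-2-yl with the highest number among the three groups. On these data alone, it remains open whether that number depends on the thiophene ring or on its methyl group, and whether a morpholine or a simple amine at this position would keep it. No measurement here explains the differences between these groups.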